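This account rests on a few compounds, and the source may have more. Where it says the series, first, only, none or still open, it means among the compounds named here.

Compound 1 `CC(=O)Oc1ccccc1C(=O)O[C@H]1CO[C@H]2[C@@H]1OC[C@H]2OC(=O)c1ccc(O)cc1` stands lowest of the three compounds examined in an ADME assay on a cell-free system (plasma, Homo sapiens) for metabolic stability, with Plasma (Rattus norvegicus) as the target, read by HPLC, at pH 7.4 (on this read-out higher numbers stand for a longer-lived compound and lower numbers for a shorter-lived compound), at 0.0198 h. Compound 3 `CC(=O)Oc1ccccc1C(=O)O[C@H]1CO[C@H]2[C@@H]1OC[C@H]2OC(=O)c1ccc([N+](=O)[O-])cc1` reaches 0.0462 h, and compound 2 `CC(=O)Oc1ccccc1C(=O)O[C@H]1CO[C@H]2[C@@H]1OC[C@H]2OC(=O)c1cccc(C)c1` reaches 0.165 h. Compound 4 `CC(=O)Oc1ccccc1C(=O)O[C@H]1CO[C@H]2[C@@H]1OC[C@H]2OC(=O)c1ccc(C#N)cc1` differs from compound 1 by cyano in place of hydroxy on an aromatic carbon. For the measured compounds named here, two measured steps bear on this change: the one in which nitro took the place of hydroxy on the same aromatic carbon, a 2.3-fold higher number from compound 1 to compound 3 (0.37 log units; beyond the scatter), and the broader one in which 3-methylphenyl took the place of 4-hydroxyphenyl on the carbonyl carbon, an 8.3-fold higher number from compound 1 to compound 2 (0.92 log units; beyond the scatter); between those two products there was a 3.6-fold lower number from compound 2 to compound 3 (0.55 log units; beyond the scatter). Because the replacement of hydroxy by nitro gave a 2.3-fold higher number from compound 1 to compound 3 (0.37 log units; beyond the scatter), compound 4 is expected to show a modest rise of similar size, a 2.5-fold higher number from compound 1 to compound 4 (0.40 log units; beyond the scatter). Compound 4 is therefore estimated at 0.05 h, within a range from 0.02 h to 0.12 h.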

Compound 4, half-life: 0.0888 h
Compound 4: middle estimate off by 1.8-fold (0.25 log units), on the low side; measured number inside the range.
By their numbers in this assay, from the lowest: compound 1; then compounds 3, 4 and 2 (each within the scatter of the next, the first and the last beyond it).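

Cyano in place of hydroxy gave a 4.5-fold higher number from compound 1 to compound 4 (0.65 log units; beyond the scatter) and so, after nitro, is a second replacement at this position that lies beyond the scatter of compound 1. The two replacing groups are not told apart, since the step of a 1.9-fold higher number from compound 3 to compound 4 (0.28 log units; within the scatter) stays within the scatter. The step of a 1.9-fold lower number from compound 2 to compound 4 (0.27 log units; within the scatter) also stays within it, and nothing on hand accounts for these numbers.

From the compounds shown here alone, whether an amine, a carboxylic acid or a methoxy group at this position would read like hydroxy or like cyano and nitro remains open.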